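Thiophene in place of hydroxyphenyl on the thiosemicarbazone arm

A few compounds are considered here, and "the series" means these few. Any claim that something is new, unique, unknown or untested is made for them only; others in the source may bear on it.

Compound 1 `CC1=CC[C@H](C(C)(C)NC(=S)N/N=C/c2ccc(O)cc2)CC1` is the hydroxyphenyl member without further substitution. In a functional assay on U-251 cells (Homo sapiens) for inhibition, read by sulforhodamine B assay, with a stated time of 48 h (on this read-out higher numbers stand for weaker inhibition of growth and lower numbers for stronger inhibition of growth), compound 1 reaches only the limit > 100000 nM, which is a limit and not a number. Compound 2 `COc1cc(/C=N/NC(=S)NC(C)(C)[C@H]2CC=C(C)CC2)ccc1O` carries a methoxy in place of hydrogen on an aromatic carbon; in this assay compound 2 gives 32600 nM. That change produced an at least 3.0-fold lower number from compound 1 to compound 2 (0.48 log units; beyond the scatter), though the size is open because compound 1 sits at the limit of > 100000 nM in this assay, at which 1 of the 2 values shown sits.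

Compound 3 `CC1=CC[C@H](C(C)(C)NC(=S)N/N=C/c2cccs2)CC1` differs from compound 1 by thiophen-2-yl in place of 4-hydroxyphenyl on a carbon with a double bond to nitrogen. Within the data shown here, no measured step covers this exchange; the only measured step, from compound 1 to compound 2, concerns a different place in the structure and shows merely that compound 1 can be bettered. For compound 3 in this assay the expected step is an at least 1.2-fold lower number from compound 1 to compound 3 (0.09 log units; that floor lies within the scatter), with no direction assured beyond the scatter. Compound 3 is estimated at 80000 nM, within 20000 nM to 150000 nM.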

Compound 3, concentration for total growth inhibition: 27400 nM
Compound 3: the middle estimate sits 2.9-fold (0.47 log units) above what was measured; low and high end bracket the measured number.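

In this assay, replacing the whole ring at this carbon with a double bond to nitrogen gives an at least 3.6-fold lower number from compound 1 to compound 3 (0.56 log units; beyond the scatter), so this position allows more than added substitution on the 4-hydroxyphenyl ring. The thiophen-2-yl group carries no hydrogen-bond donor, so the hydroxyl donor of compound 1 is not required for a measured number here, and compound 2 at 32600 nM and compound 3 at 27400 nM show no order, as the two values lie within the usual scatter. Compound 1 stands at a limit and not a number, so the size of this step stays open: the limit of > 100000 nM in this assay, at which 1 of the 3 values shown sits.

The compounds shown do not separate the contributions of the sulfur, the ring size and the loss of the hydroxyl. A plain phenyl or a furan-2-yl group on the same carbon would bear on that question.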